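This account rests on a few compounds, and the source may have more. Where it says the series, first, only, none or still open, it means among the compounds named here.

Measured so far:
- compound 1, `CCCCCCCC(=O)Nc1nnc(S[C@@H]2O[C@H](CO)[C@H](O)[C@H](O)[C@H]2O)s1`: 60100 nM
- compound 2, `CCCCCCCCCCCCCCCC(=O)Nc1nnc(S[C@@H]2O[C@H](COC(C)=O)[C@H](OC(C)=O)[C@H](OC(C)=O)[C@H]2OC(C)=O)s1`: 90400 nM

In an ADME assay on CHO-K1 cells (Cricetulus griseus) for cytotoxicity, read by MTT assay, with a stated time of 24 h (on this read-out higher numbers stand for weaker inhibition and lower numbers for stronger inhibition), compound 1 gives 60100 nM, the lowest of the two numbers; compound 2 gives 90400 nM, and the two values lie within the scatter of each other, so no order between them can be read. Among the measured compounds shown here, compound 2 also carries acetyl groups on the sugar that compound 1 lacks, and no single step links the two.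

The unmeasured compound 3, `CCCCCCCCCCCCCCCC(=O)Nc1nnc(S[C@@H]2O[C@H](CO)[C@H](O)[C@H](O)[C@H]2O)s1`, differs from compound 1 by a single change: octyl in place of hydrogen on a saturated chain carbon, seven bonds along the chain from a carbonyl carbon.

Both measured values sit close together despite different chain lengths, which gives little ground for expecting a large shift. The step from compound 1 to compound 3 in this assay is expected to be small, at most a modest rise in the number, as a 1.3-fold higher number from compound 1 to compound 3 (0.12 log units; within the scatter). Compound 3 is therefore estimated at 80000 nM, with a range of 40000 nM to 160000 nM.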

Compound 3, half-maximal inhibitory concentration: "not active" (no number reported)
Compound 3: no number reported, so the estimate cannot be set against anything.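

In this assay, among the compounds shown here, compound 3 is reported as "not active" without a number, so no step from compound 1 can be read. Nothing at hand bears on this result. The compounds shown leave open what octyl in place of hydrogen does to the read-out.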